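The source may report more compounds than this note shows. Statements on the series, on what has been measured and on what is new or still open speak of the compounds shown alone.

Compound 1 `Cc1noc(NS(=O)(=O)c2cccc3c(NC(=O)C(C)C)cccc23)c1C`: 880 nM. Compound 2 `Cc1noc(NS(=O)(=O)c2cccc3c(N4CCCCC4=O)cccc23)c1C`: 270 nM. Compound 3 `CN(C)c1cccc2c(S(=O)(=O)Nc3onc4c3CCCC4)cccc12`: 153000 nM.

In an assay on VSM-A10 cells for antagonist activity at Endothelin-1 receptor (Rattus norvegicus) (on this read-out higher numbers stand for weaker inhibition and lower numbers for stronger inhibition), compound 2 stands at the lowest of the three numbers; the nearest is compound 1, the furthest compound 3. Compound 4 `CNc1cccc2c(S(=O)(=O)Nc3onc(C)c3C)cccc12` has not yet been measured. It differs from compound 2 in one place: methylamino in place of 2-oxopiperidin-1-yl on an aromatic carbon.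

For the measured compounds named here, only one measured step concerns that same place, a 3.3-fold lower number from compound 1 to compound 2 (0.51 log units; beyond the scatter), and it exchanged one carbonyl-bearing group for another; the group entering in compound 4 carries no carbonyl, so that step gives little direct guidance. Compound 3, which bears a dimethylamino group together with a different ring on the other side of the sulfonamide, gives 153000 nM, a number far above that of compound 2, though two changes separate the pair and no single step can be read from it. On this evidence the number for compound 4 is expected to rise, a 19-fold higher number from compound 2 to compound 4 (1.27 log units; beyond the scatter), to an estimated 5000 nM with a range from 800 nM to 30000 nM.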

Compound 4, half-maximal inhibitory concentration: 130 nM
Beside the measured number, compound 4's estimate is 38-fold (1.59 log units) above it; measured number outside the range, below it.
By their numbers in this assay, from the lowest: compound 4; then compound 2; then compound 1; then compound 3.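

In this assay, the step of a 2.1-fold lower number from compound 2 to compound 4 (0.32 log units; beyond the scatter) and the step of a 6.8-fold lower number from compound 1 to compound 4 (0.83 log units; beyond the scatter) both run towards the methylamino group, so this aromatic carbon needs neither a carbonyl nor a non-aromatic ring in its substituent for inhibition at this level. Of the three groups compared on the shared core, the one without a carbonyl gives the lowest number, which the earlier carbonyl-to-carbonyl step could not show. No measurement shown here explains the change.

The compounds leave open whether a free amine or an ethylamino group at this place would go on lowering the number or raise it. The effect of dimethylamino here also remains unresolved, since compound 3 differs from compound 4 in more than this one place.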